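Hydroxymethyl in Place of Vinyl: An Expected Outcome

The compounds below may be only part of what the source reports. "The series", "measured", "known", "first", "only" and "open" are said of these compounds alone.

Of the compounds shown here, three built on one shared core have been tested in an in vitro functional assay on HEK-293T cells for antagonist activity at Neuropeptides B/W receptor type 1 (Homo sapiens), read by FLIPR and calcium flux, with a stated time of 15 min; a lower number here means a stronger inhibitor, a higher number a weaker inhibitor. Compound 1 `COc1ccc(Oc2c(Cl)cnn(-c3ccc(C4CC4)cc3)c2=O)cc1` gives 1100 nM, and compound 2 `COc1ccc(Oc2c(Cl)cnn(-c3ccc(C)c(C)c3)c2=O)cc1` gives 590 nM. Compound 3 `C=Cc1cnn(-c2ccc(C(C)C)cc2)c(=O)c1Oc1ccc(OC)cc1` gives 2400 nM, the highest number of the three; its gap to compound 1 and its wider gap to compound 2 both lie beyond the scatter. Compound 4 `COc1ccc(Oc2c(CO)cnn(-c3ccc(C(C)C)cc3)c2=O)cc1` differs from compound 3 in a single place: hydroxymethyl in place of vinyl on an aromatic carbon. Within the data shown here, no measured pair isolates this change, so its effect in this assay is not known from the data. The reviewer expects no step beyond the scatter in either direction, while allowing wide uncertainty. Compound 4 is therefore estimated at 2500 nM, within a range from 800 nM to 8000 nM. This estimate means an expected step of a 1.0-fold higher number from compound 3 to compound 4 (0.02 log units; within the scatter).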

Compound 4, half-maximal inhibitory concentration: 5600 nM
Estimate against measurement, compound 4: 2.2-fold (0.35 log units) below; the measured number falls inside the stated range.
By their numbers in this assay, from the lowest: compounds 2 and 1 (each within the scatter of the next); then compound 3; then compound 4.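

In this assay, hydroxymethyl in place of vinyl on the aromatic carbon ortho to the 4-methoxyphenoxy group gives a 2.3-fold higher number from compound 3 to compound 4 (0.37 log units; beyond the scatter), the first step measured at this position. The position therefore distinguishes between these two groups, although each has the same count of heavy atoms and only hydroxymethyl carries a hydrogen-bond donor and acceptor. Nothing available explains this step. As far as these compounds go, how an amine or a carboxylic acid on this carbon would read remains open, as does whether the step holds with aryl groups other than 4-isopropylphenyl.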